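Flipping One Ring Carbon in a Pyrrolidine Carboxamide

The source may hold more compounds than are shown below. What is called first, only, known or untested is meant among the compounds shown, and "the series" means these compounds.

Compound 1 `C[C@@H]1C[C@@H](C(N)=O)N(Cc2ccc(OCc3cccc(F)c3)cc2)C1` — in an assay on Sf9 cells for inhibition of Amine oxidase [flavin-containing] B (Homo sapiens), with stated times of 15 min and 60 min (on this read-out higher numbers stand for weaker inhibition and lower numbers for stronger inhibition), compound 1 gives 2180 nM
Compound 2 `NC(=O)[C@@H]1C[C@H](O)CN1Cc1ccc(OCc2cccc(F)c2)cc1` — in this assay compound 2 gives 431 nM

Among the two measured compounds, compound 2 holds the lower number, so it is the stronger inhibitor, and its gap to compound 1 lies beyond the usual scatter. The next compound, compound 3 `NC(=O)[C@@H]1C[C@@H](O)CN1Cc1ccc(OCc2cccc(F)c2)cc1`, has not yet been measured. Compared with compound 2, (the two compounds have the same atoms and bonds and differ only in configuration as drawn: 1 of 2 stereo elements differ; a stereocentre at a saturated ring carbon is drawn S in compound 2 and R in compound 3). Among the measured compounds shown here, no measured pair shows what such a flip of configuration does here, so there is no direct guide. A change at a single ring carbon of this kind can move the number either way, and usually by a moderate amount rather than by a very large one. Compound 3 is therefore expected to give roughly 800 nM, somewhere between 250 nM and 3000 nM, which is expected to correspond to a step of a 1.9-fold higher number from compound 2 to compound 3 (0.27 log units; within the scatter).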

Compound 3, half-maximal inhibitory concentration: > 10000 nM
Compound 3 ended at the assay's limit; the forecaster's own chance of this, stated with the estimate: 5%; at least 12-fold (1.09 log units) between middle value and limit.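

In this assay, among the compounds shown here, the configuration at the ring carbon carrying the hydroxy group matters far more than the earlier compounds could show, with an at least 23-fold higher number from compound 2 to compound 3 (1.36 log units; beyond the scatter), and this gap can be traced to that single centre: the fact that compounds 2 and 3 differ only in the configuration as drawn. The value of compound 3, > 10000 nM, is a limit of the assay and not a number. With the configuration drawn in compound 3, hydroxy in place of methyl on a saturated ring carbon brings no gain, giving an at least 4.5-fold higher number from compound 1 to compound 3 (0.66 log units; beyond the scatter).

Going by these compounds, how far compound 3 really lies from compound 2 remains unknown, since only a lower bound on that gap can be read. Also open, on these data alone, is whether an amine or a methoxy group on this ring carbon would show the same sharp dependence on configuration.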